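Acyl group swap on the amide carbonyl: compound 2 to compound 3

A few compounds are considered here, and "the series" means these few. Any claim that something is new, unique, unknown or untested is made for them only; others in the source may bear on it.

Measured in a functional assay on U-87MG ATCC cells (Homo sapiens) for antiproliferative activity; a lower number here means a stronger inhibitor, a higher number a weaker inhibitor:
- compound 1 `Cc1c2c(n3c1CCN(C)C[C@@H](C)[C@H](C)Nc1cc-3ccc1C(N)=O)CC(C)(C)CC2=O`: 49 nM
- compound 2 `Cc1c2c(n3c1CCN(C(=O)C1(N)CCCC1)C[C@@H](C)[C@H](C)Nc1cc-3ccc1C(N)=O)CC(C)(C)CC2=O`: 44 nM

Compound 2 stands level with compound 1 on these numbers, the two values lying within the scatter of each other. Compound 3 `Cc1c2c(n3c1CCN(C(=O)[C@@H](O)C(C)C)C[C@@H](C)[C@H](C)Nc1cc-3ccc1C(N)=O)CC(C)(C)CC2=O` keeps the shared core and carries 1-hydroxy-2-methylpropyl in place of 1-aminocyclopentyl on a carbonyl carbon . Among the measured compounds shown here, one measured step bears on this change: a 1.1-fold lower number from compound 1 to compound 2 (0.05 log units; within the scatter) stays within the scatter even though a whole group of atoms enters on the amine nitrogen in a ring. For the measured compounds named here, no measured compound carries 1-hydroxy-2-methylpropyl, so this support is indirect. No step beyond the scatter is expected in this assay, and no direction is favoured. The estimated 1.1-fold higher number from compound 2 to compound 3 (0.06 log units; within the scatter) therefore stays small. Compound 3 is expected at 50 nM, with an estimated range of 20 nM to 130 nM.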

Compound 3, half-maximal inhibitory concentration: 76 nM
Beside the measured number, compound 3's estimate is 1.5-fold (0.18 log units) below it; the measured number falls inside the stated range.
By their numbers in this assay, from the lowest: compounds 2, 1 and 3 (each within the scatter of the next).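

In this assay, a second acyl group can now be read on the carbonyl carbon: 1-hydroxy-2-methylpropyl in place of 1-aminocyclopentyl gives a 1.7-fold higher number from compound 2 to compound 3 (0.24 log units; within the scatter), so an open-chain group with 1 defined stereocentre stays level with the ring-bearing group. Set against methyl on the amine nitrogen in a ring, the same acyl group gives a 1.6-fold higher number from compound 1 to compound 3 (0.19 log units; within the scatter), so methyl and both acyl groups on that nitrogen cannot yet be told apart in this assay. No supporting data explain these numbers.

As far as these compounds go, whether a carboxylic acid or a longer chain on the carbonyl carbon would produce a step beyond the scatter remains open. Also open, from the compounds shown here alone, is how plain cyclopentyl, without the amine, would compare with 1-aminocyclopentyl at this place.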